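Swapping one para substituent in a benzimidazole-pyrazole toxicity series

This account rests on a few compounds, and the source may have more. Where it says the series, first, only, none or still open, it means among the compounds named here.

Of the compounds shown here, three have been measured in an ADME assay on HEK-293T cells (Homo sapiens) for cytotoxicity, read by MTT assay, with a stated time of 24 h; on this read-out lower numbers stand for higher toxicity in this test and higher numbers for lower toxicity in this test. Compound 3 `O=C(c1ccc(Cl)cc1)n1c(-c2cn(-c3ccccc3)nc2-c2ccc(F)cc2)nc2ccccc21` gives 179000 nM. Compound 1 `Cc1ccc(C(=O)n2c(-c3cn(-c4ccccc4)nc3-c3ccc(F)cc3)nc3ccccc32)cc1` gives 178000 nM. Compound 2 `Cc1ccc(-c2nn(-c3ccccc3)cc2-c2nc3ccccc3n2C(=O)c2ccc(Cl)cc2)cc1` gives 216000 nM. Compound 4 `Cc1ccc(C(=O)n2c(-c3cn(-c4ccccc4)nc3-c3ccc(C)cc3)nc3ccccc32)cc1` is not yet measured.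

From compound 3 to compound 1 the change is methyl in place of chloro on an aromatic carbon, and the step is a 1.0-fold lower number from compound 3 to compound 1 (0.00 log units; within the scatter). The same change, (methyl in place of chloro on an aromatic carbon), turns compound 2 into compound 4; the place where it happens reads the same in both pairs. The two cores differ by methyl in place of fluoro on an aromatic carbon, and the step from compound 2 to compound 3 is a 1.2-fold lower number from compound 2 to compound 3 (0.08 log units; within the scatter).

Because a 1.0-fold lower number from compound 3 to compound 1 (0.00 log units; within the scatter) hardly moved the number, the step from compound 2 to compound 4 is expected to be a 1.0-fold lower number from compound 2 to compound 4 (0.01 log units; within the scatter). Compound 4 is therefore estimated at 210000 nM, expected to lie between 130000 nM and 340000 nM.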

Compound 4, half-maximal cytotoxic concentration: 176000 nM
For compound 4 the middle estimate is 1.2-fold (0.08 log units) above the measured one; measured number inside the range.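

In this assay, methyl in place of chloro gives a 1.2-fold lower number from compound 2 to compound 4 (0.09 log units; within the scatter) and this step matches the earlier one on the other core: the same change on two cores in this assay, a 1.0-fold lower number (0.00 log units; within the scatter) from compound 3 to compound 1 and a 1.2-fold lower number (0.09 log units; within the scatter) from compound 2 to compound 4, 1.2-fold (0.09 log units) apart, within the scatter of two such steps. Methyl in place of fluoro gives a 1.0-fold lower number from compound 1 to compound 4 (0.00 log units; within the scatter) and it also reads alike on both cores: the same change on two cores in this assay, a 1.2-fold lower number (0.08 log units; within the scatter) from compound 2 to compound 3 and a 1.0-fold higher number (0.00 log units; within the scatter) from compound 4 to compound 1, 1.2-fold (0.09 log units) apart, within the scatter of two such steps. So both changes carry across these two cores, but only as steps too small to separate from the scatter, which does not show that any of these groups moves the number or that a larger step would carry over.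

The compounds shown leave open whether a different group at these places, such as an amine or a carboxylic acid, would shift the number beyond the scatter. They also leave open whether cores other than these would behave alike.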